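The source may hold more compounds than are shown below. What is called first, only, known or untested is meant among the compounds shown, and "the series" means these compounds.

Working notes on the series, read in a functional assay on DU-145 cells (Homo sapiens) for inhibition, read by trypan blue exclusion, with a stated time of 96 h; on this read-out lower numbers stand for stronger inhibition of growth and higher numbers for weaker inhibition of growth. Compound 1 `Cc1ccc(S/C(=C/c2ccc(F)c(C)c2)C(=O)c2ccc(Br)cc2)cc1` gives 25000 nM. Compound 2 `Cc1ccc(S/C(=C/c2ccc(Oc3ccccc3)cc2)C(=O)c2ccc(Br)cc2)cc1` gives 1000 nM. Compound 3 `Cc1ccc(S/C(=C/c2ccc(F)cc2F)C(=O)c2ccc(Br)cc2)cc1` gives > 100000 nM, and this is a limit of the assay, not a number.

Next comes compound 4 `CC(=O)c1ccc(/C=C(/Sc2ccc(C)cc2)C(=O)c2ccc(Br)cc2)cc1`, with the change 4-acetylphenyl in place of 2,4-difluorophenyl on a double-bonded chain carbon bound to a double-bonded chain carbon. Going by the values given here, the one measured step at this place is an at least 4.0-fold higher number from compound 1 to compound 3 (0.60 log units; beyond the scatter), with 2,4-difluorophenyl entering in place of 4-fluoro-3-methylphenyl. On these data alone, that step is bounded on one side only, so its full size is unknown. It does tie the 2,4-difluorophenyl group to weaker inhibition of growth, so removing that group is expected to lower the number by more than the scatter. Compound 2 also carries a different group at this place and gives 1000 nM, while compound 1 gives 25000 nM; these two values mark the span used for the expectation. Among the compounds with values here, no measured step involves the 4-acetylphenyl group, so the range stays wide. The expected change is an at least 6.6-fold lower number from compound 3 to compound 4 (0.82 log units; beyond the scatter). For compound 4 the estimate is 15000 nM, with an expected range from 2500 nM to 80000 nM.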

Compound 4, concentration for 50% growth inhibition: 50000 nM
Estimate against measurement, compound 4: 3.3-fold (0.52 log units) below; the range from low to high includes it.
By their numbers in this assay, from the lowest: compound 2; then compounds 1 and 4 (each within the scatter of the next). At a limit, above all of these: compound 3.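

In this assay, the step of an at least 2.0-fold lower number from compound 3 to compound 4 (0.30 log units; that floor lies within the scatter) starts from a limit and gives only a floor, so it does not firmly separate 4-acetylphenyl from 2,4-difluorophenyl; compound 3 stands at that limit, which is not a number: the limit of > 100000 nM in this assay, at which 1 of the 4 values shown sits. The step of a 2.0-fold higher number from compound 1 to compound 4 (0.30 log units; within the scatter) shows that 4-acetylphenyl and 4-fluoro-3-methylphenyl are not told apart at this place, even though they share no substituent. Going by these compounds alone, the step of a 50-fold higher number from compound 2 to compound 4 (1.70 log units; beyond the scatter), with acetyl in place of phenoxy on an aromatic carbon, is the first printed step that involves phenoxy, and it sets compound 2 clearly apart from compound 4.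

The compounds shown leave open whether the difference tied to phenoxy goes with its second aromatic ring or with its ether oxygen, a question on which a benzyl or a methoxy group on the same aromatic carbon would bear. Also open, on these data alone, is how an amine or a carboxylic acid on that carbon would read, and how far compound 3 really lies from the others.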